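From acetyl to methylsulfonyl: what compound 3 may show

A few compounds are considered here, and "the series" means these few. Any claim that something is new, unique, unknown or untested is made for them only; others in the source may bear on it.

- Compound 1 (`C[C@]1(c2ccc(F)cc2)CN(C(=O)NCc2ccncc2)C[C@H]1c1ccc(C(O)(C(F)(F)F)C(F)(F)F)cc1`) gives 11% 
- Compound 2 (`CC(=O)N1CCC(C(=O)N2C[C@@H](c3ccc(C(O)(C(F)(F)F)C(F)(F)F)cc3)[C@@](C)(c3ccc(F)cc3)C2)CC1`) gives 86% 

In an ADME assay on microsomes from liver (Homo sapiens) for metabolic stability, with a stated time of 10 min (a higher number here means that more of the compound is left, a lower number that less of the compound is left), compound 2 stands highest of the two measured compounds with 86% and lies well clear of compound 1. Compound 3 (`C[C@]1(c2ccc(F)cc2)CN(C(=O)C2CCN(S(C)(=O)=O)CC2)C[C@H]1c1ccc(C(O)(C(F)(F)F)C(F)(F)F)cc1`) is still unmeasured and differs from compound 2 in one place: methylsulfonyl in place of acetyl on an amine nitrogen in a ring. Going by the values given here, the only measured step (a number 75 percentage points higher from compound 1 to compound 2 (beyond the scatter)) is large and beyond the scatter. Among the compounds with values here, that step exchanged the whole group on the carbonyl carbon, whereas compound 3 changes only the group on the ring nitrogen, so no measured step tests this change directly. Only a small change is therefore expected: a number 6 percentage points lower from compound 2 to compound 3 (within the scatter) is estimated to stay within the scatter. In this assay the expected value for compound 3 is 80% (estimated range 62% to 93%).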

Compound 3, percent of the compound remaining: 90%
Estimate against measurement, compound 3: 10 percentage points below; measured number inside the range.
By their numbers in this assay, from the lowest: compound 1; then compounds 2 and 3 (each within the scatter of the next).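

In this assay, putting methylsulfonyl in place of acetyl on the amine nitrogen in the ring gives a number 4 percentage points higher from compound 2 to compound 3 (within the scatter) and so makes no difference that can be told from the scatter at this position. The large step seen earlier is therefore not tied to acetyl alone: a number 79 percentage points higher from compound 1 to compound 3 (beyond the scatter) and matches the earlier step in kind, now with a second group on that ring nitrogen. Nothing measured here gives a reason for either step.

Still open, on these data alone, is whether that ring nitrogen would give a similar number with a plain methyl, a free amine hydrogen or a longer chain such as ethylsulfonyl. As far as these compounds go, it also remains open which part of the ((pyridin-4-yl)methyl)amino group goes with the low number of compound 1, such as the pyridine or the amide hydrogen.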